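The source may report more compounds than this note shows. Statements on the series, on what has been measured and on what is new or still open speak of the compounds shown alone.

Measured in a functional assay on SNB-75 cells (Homo sapiens) for cytotoxicity, read by sulforhodamine B assay, with a stated time of 48 h; on this read-out lower numbers stand for stronger inhibition of growth and higher numbers for weaker inhibition of growth:

compound 1 `ClCc1ccccc1Cn1cnc2c(Cl)nc(Cl)nc21`: 3540 nM
compound 2 `ClCc1ccccc1Cn1cnc2c(Cl)ncnc21`: 11000 nM
compound 3 `ClCc1ccccc1Cn1cnc2ncnc(Cl)c21`: 26900 nM

Compound 3 gives the highest of the three numbers. Compounds 2 and 3 are built from the same atoms joined differently; the difference between the two cores is not broken down here. Within the core of compound 2, the change chloro in place of hydrogen on an aromatic carbon gave a 3.1-fold lower number from compound 2 to compound 1 (0.49 log units; beyond the scatter), a step beyond the scatter. Compound 4 `ClCc1ccccc1Cn1cnc2nc(Cl)nc(Cl)c21` is not yet measured; it carries the same change on the core of compound 3, (chloro in place of hydrogen on an aromatic carbon), with its surroundings described in the same words as for compound 1. The expectation for compound 4 rests on compound 3 with 26900 nM and on the step of a 3.1-fold lower number from compound 2 to compound 1 (0.49 log units; beyond the scatter). On that basis a step of a 3.0-fold lower number from compound 3 to compound 4 (0.48 log units; beyond the scatter) is expected for compound 4. The estimate for compound 4 is 9000 nM, expected between 3500 nM and 22000 nM.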

Compound 4, concentration for total growth inhibition: 4460 nM
The estimate for compound 4 lay 2.0-fold (0.30 log units) above the measured number; measured number inside the range.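

In this assay chloro in place of hydrogen on an aromatic carbon gives a 6.0-fold lower number from compound 3 to compound 4 (0.78 log units; beyond the scatter) on the core of compound 3, the same direction as on the core of compound 2. The two steps cannot be told apart in size: the same change on two cores in this assay, a 3.1-fold lower number (0.49 log units; beyond the scatter) from compound 2 to compound 1 and a 6.0-fold lower number (0.78 log units; beyond the scatter) from compound 3 to compound 4, 1.9-fold (0.29 log units) apart, within the scatter of two such steps. This shows the change carrying over between these two cores in this one assay, but two pairs do not show that it would carry to any other core, and they give no reason for the step.

Open, from the compounds shown here alone, is whether an amine or a methoxy group on the same carbon, between two ring nitrogen atoms, would give a matching step on both cores.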